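The source may report more compounds than this note shows. Statements on the series, on what has been measured and on what is new or still open speak of the compounds shown alone.

Measured so far, in an ADME assay on HepG2 cells (Homo sapiens) for cytotoxicity, read by luminescence, with a stated time of 72 h; on this read-out higher numbers stand for an effect only at larger amounts of compound and lower numbers for an effect already at smaller amounts:
Compound 1, `CCOC(=O)c1c(-c2cccc(C)c2)[nH]c2cc(OC)ccc2c1=O`, gives > 21500 nM, a limit of the assay.
Compound 2, `C=Cc1cccc(-c2[nH]c3cc(OC)ccc3c(=O)c2C(=O)OCC)c1`, gives > 21500 nM, again a limit.
Compound 3, `CCOC(=O)c1c(-c2cccc(Cl)c2)[nH]c2cc(OC)ccc2c1=O`, gives > 21500 nM, also a limit.

Compound 1 therefore stands not at a number but at the limit of > 21500 nM in this assay, at which 3 of the 3 values shown sit. Compound 4, `CCOC(=O)c1c(-c2cccc(NC(C)=O)c2)[nH]c2cc(OC)ccc2c1=O`, differs from it in one place: acetamido in place of methyl on an aromatic carbon. Going by the values given here, the steps that bear on this are the two that swap the same methyl, a step that the two limits leave unreadable from compound 1 to compound 2 and a step that the two limits leave unreadable from compound 1 to compound 3, and the related step that the two limits leave unreadable from compound 2 to compound 3; none of them gave a readable size, so there is no measured ground for any direction. For compound 4 a value at the same limit is expected, 30000 nM (range 15000 nM to 90000 nM). The step expected from compound 1 to compound 4 is a step that the limit leaves unreadable from compound 1 to compound 4, that is, none that the assay could show.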

Compound 4, half-maximal effective concentration: > 21500 nM
Compound 4: no number, only a limit; the forecaster's own chance of this, stated with the estimate: 85%; the middle value does not contradict the limit.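

In this assay, going by these compounds alone, compound 4 gives only a limit, as do compound 1, compound 2 and compound 3, so no step among them can be read: the limit of > 21500 nM in this assay, at which 4 of the 4 values shown sit.

The compounds shown leave open where each true value lies and whether the four differ at all.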